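Meta substituent swap on a triazole-linked bicyclic lactam

The compounds below may be only part of what the source reports. "The series", "measured", "known", "first", "only" and "open" are said of these compounds alone.

Compound 1 `CC1(C)[C@H]2CC[C@]1(C)N(Cc1cn(-c3cccc(F)c3)nn1)C(=O)C2` gives 80 nM in a functional assay on HepG2 cells (Homo sapiens) for inhibition, read by MTT assay, with a stated time of 24 h; on this read-out lower numbers stand for stronger inhibition and higher numbers for weaker inhibition.
Compound 2 `CC1(C)[C@H]2CC[C@]1(C)N(Cc1cn(-c3ccccc3C#N)nn1)C(=O)C2` gives 180 nM in this assay.
Compound 3 `CC1(C)[C@H]2CC[C@]1(C)N(Cc1cn(-c3cccc(Cl)c3)nn1)C(=O)C2` gives 60 nM in this assay.

Compound 3 stands at the lowest of the three numbers: one of its two steps is a 1.3-fold lower number from compound 1 to compound 3 (0.12 log units; within the scatter), within the scatter, and the other is a 3.0-fold lower number from compound 2 to compound 3 (0.48 log units; beyond the scatter). Compound 4 `Cc1cccc(-n2cc(CN3C(=O)C[C@@H]4CC[C@@]3(C)C4(C)C)nn2)c1` differs from compound 3 by methyl in place of chloro on an aromatic carbon. Going by the values given here, only one measured step changes a group on that aromatic carbon, namely a 1.3-fold lower number from compound 1 to compound 3 (0.12 log units; within the scatter), and it stayed within the scatter, so no step beyond the scatter is expected here either. Compound 4 is therefore estimated at 70 nM, range 35 nM to 140 nM, an expected step of a 1.2-fold higher number from compound 3 to compound 4 (0.07 log units; within the scatter).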

Compound 4, half-maximal inhibitory concentration: 300 nM
The estimate for compound 4 lay 4.3-fold (0.63 log units) below the measured number; measured number above the stated range.
By their numbers in this assay, from the lowest: compounds 3 and 1 (each within the scatter of the next); then compounds 2 and 4 (each within the scatter of the next).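

In this assay, the group on this aromatic carbon turns out to matter: a 5.0-fold higher number from compound 3 to compound 4 (0.70 log units; beyond the scatter), and a 3.8-fold higher number from compound 1 to compound 4 (0.57 log units; beyond the scatter), whereas the swap between fluoro and chloro stayed within the scatter. With a 1.7-fold higher number from compound 2 to compound 4 (0.22 log units; within the scatter), the 3-methylphenyl and 2-cyanophenyl groups cannot be told apart here. Nothing measured explains why methyl departs from both halogens. The compounds shown leave open how a methoxy, a trifluoromethyl or an amine on this aromatic carbon would read.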